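A few compounds are considered here, and "the series" means these few. Any claim that something is new, unique, unknown or untested is made for them only; others in the source may bear on it.

Compound 1 `CC(=O)N1CCC(C(=O)N(CCCN2CCC(Oc3ccccc3)CC2)c2ccc(C)c(Cl)c2)CC1`: > 56600 nM, a limit.
Compound 2 `CC(=O)N1CCC(C(=O)N(CCCN2CCN(Cc3ccncc3)CC2)c2ccc(C)c(Cl)c2)CC1`: > 56700 nM, a limit.
Compound 3 `CC(=O)N1CCC(C(=O)N(CCCN2CCN(Cc3ccc(Cl)cc3)CC2)c2ccc(C)c(Cl)c2)CC1`: 37600 nM.

In an ADME assay (Homo sapiens) for cytotoxicity (on this read-out higher numbers stand for lower toxicity in this test and lower numbers for higher toxicity in this test), compound 1 gives only a limit, > 56600 nM. Compound 2 likewise gives only a limit, > 56700 nM. Within the data shown here, compound 3 gives 37600 nM, the only plain number among the three. Among the measured compounds shown here, the one step measured at the relevant position is an at least 1.5-fold lower number from compound 2 to compound 3 (0.17 log units; that floor lies within the scatter), and its floor lies within the scatter. Compound 4 `CC(=O)N1CCC(C(=O)N(CCCN2CCN(Cc3cnc(Cl)s3)CC2)c2ccc(C)c(Cl)c2)CC1` differs from compound 3 by 2-chloro-1,3-thiazol-5-yl in place of 4-chlorophenyl on a saturated chain carbon bound to an amine nitrogen in a ring. For the measured compounds named here, since the only comparable step, an at least 1.5-fold lower number from compound 2 to compound 3 (0.17 log units; that floor lies within the scatter), is small, the author expects no change beyond the scatter in this assay, possibly a drift back toward the limit, as compound 2 showed; the expected step is a 1.2-fold higher number from compound 3 to compound 4 (0.08 log units; within the scatter). Compound 4 is therefore estimated at 45000 nM, between 20000 nM and 100000 nM.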

Compound 4, half-maximal cytotoxic concentration: > 52300 nM
Compound 4: a limit, no number; the forecaster's own chance of this, stated with the estimate: 40%; middle value at least 1.1-fold (0.06 log units) away from the limit.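

With 2-chloro-1,3-thiazol-5-yl on this saturated chain carbon, compound 4 gives only a limit in this assay: the limit of > 52300 nM in this assay, at which 1 of the 4 values shown sits.

The change from 4-chlorophenyl is an at least 1.3-fold higher number from compound 3 to compound 4 (0.14 log units; that floor lies within the scatter), so this change is not shown to exceed the scatter, and compound 3 remains the only compound here with a plain number. The step between the limits of compound 2 and compound 4 cannot be read.

Going by these compounds, how far the true value of compound 4 lies past its limit remains open. So does whether an unsubstituted phenyl or a 4-fluorophenyl at this place would give a plain number.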